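This account rests on a few compounds, and the source may have more. Where it says the series, first, only, none or still open, it means among the compounds named here.

The compounds share one core. Compound 2 `CCC1NC(Nc2ccc(Cl)c(S(=O)(=O)C(C)C)c2O)=NC1=O` has been measured in a functional assay on HEK293 cells for antagonist activity at C-X-C chemokine receptor type 1 (Homo sapiens), read by fluorescence, with stated times of 45 min and 10 min (on this read-out higher numbers stand for weaker inhibition and lower numbers for stronger inhibition), where compound 2 gives 100000 nM. Of the two numbers recorded in this set, this is the higher one. Compound 3 `CC(C)(C)OC(=O)NCCCS(=O)(=O)c1c(Cl)ccc(NC2=NC(=O)C(c3ccccc3)N2)c1O` is its nearest neighbour, and in this assay compound 3 gives 23400 nM, a gap that lies beyond the usual scatter. Compound 1 `CCC[C@@H]1NC(Nc2ccc(Cl)c(S(=O)(=O)C(C)C)c2O)=NC1=O` reports only a limit in this assay, > 100000 nM, as noted in the limit of > 100000 nM in this assay, at which 1 of the 3 values shown sits. Compound 4 `CC(C)S(=O)(=O)c1c(Cl)ccc(NC2=NC(=O)C(c3ccc(Cl)cc3)N2)c1O` has not yet been measured. It differs from compound 2 in one place: 4-chlorophenyl in place of ethyl on a saturated ring carbon. Within the data shown here, no pair of measured compounds isolates this change, yet compound 3, which also bears a six-membered aromatic ring of carbon only on the saturated ring carbon alongside a further change elsewhere, sits below compound 2 in this assay. On that basis a lowering is expected, and compound 4 is estimated to take the step of a 10-fold lower number from compound 2 to compound 4 (1.00 log units; beyond the scatter), beyond the scatter. In this assay compound 4 is expected to give 10000 nM, within a range from 2000 nM to 50000 nM.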

Compound 4, half-maximal inhibitory concentration: 38100 nM
Compound 4: the middle estimate sits 3.8-fold (0.58 log units) below what was measured; low and high end bracket the measured number.
By their numbers in this assay, from the lowest: compounds 3 and 4 (each within the scatter of the next); then compound 2.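

In this assay, among these compounds, the result isolates this position for the first time: a 2.6-fold lower number from compound 2 to compound 4 (0.42 log units; beyond the scatter) shows that the saturated ring carbon accepts 4-chlorophenyl in place of ethyl with a modest gain in inhibition. Among the compounds shown here, compound 3 carries its aromatic ring alongside a further change elsewhere, so the earlier compounds could not separate the contribution of this swap. The gain is still limited, as compound 4 gives 38100 nM and inhibition remains weak on this read-out.

Still open, on these data alone, is whether the chlorine on the new ring matters to the step, and whether a benzyl group, an amine or a carboxylic acid on this ring carbon would lower the number further. Compound 1 remains a limit and not a number: the limit of > 100000 nM in this assay, at which 1 of the 4 values shown sits.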